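Compound 3 to compound 4: a new group on the chain carbon

The compounds below may be only part of what the source reports. "The series", "measured", "known", "first", "only" and "open" are said of these compounds alone.

In a functional assay on MCF7 cells (Homo sapiens) for cytotoxicity, read by MTT assay, with a stated time of 72 h (a lower number here means a stronger inhibitor, a higher number a weaker inhibitor), compound 3 (`COc1cccc(C=C2C(=O)N(c3ccc(Cl)cc3)N(c3ccc(Cl)cc3)C2=O)c1OC`) gives 11900 nM and compound 1 (`COc1cc(C=C2C(=O)N(c3ccc(Cl)cc3)N(c3ccc(Cl)cc3)C2=O)ccc1O`) gives 22800 nM. These two values lie within the scatter of each other, with a 1.9-fold lower number from compound 1 to compound 3 (0.28 log units; within the scatter). Compound 2 (`COc1ccc(C=C2C(=O)N(c3ccc(Cl)cc3)N(c3ccc(Cl)cc3)C2=O)cc1OC`) gives > 128000 nM, which is a limit of the assay. Against that limit, an at least 10-fold lower number from compound 2 to compound 3 (1.03 log units; beyond the scatter) is a large step beyond the scatter, and an at least 5.6-fold higher number from compound 1 to compound 2 (0.74 log units; beyond the scatter) is also beyond it.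

Compound 4 (`O=C1C(=Cc2c[nH]c3ccccc23)C(=O)N(c2ccc(Cl)cc2)N1c1ccc(Cl)cc1`) carries 1H-indol-3-yl in place of 2,3-dimethoxyphenyl on a double-bonded chain carbon bound to a double-bonded ring carbon, with 1H-indol-3-yl in place of 2,3-dimethoxyphenyl on a double-bonded chain carbon bound to a double-bonded ring carbon. Going by the values given here, no measured step makes this kind of exchange. The nearest guide is an at least 10-fold lower number from compound 2 to compound 3 (1.03 log units; beyond the scatter), which shows that a change of group at this place can move the number strongly, and a 1.9-fold lower number from compound 1 to compound 3 (0.28 log units; within the scatter), which shows that it need not. The expected change is small, a 1.3-fold higher number from compound 3 to compound 4 (0.10 log units; within the scatter), within the scatter and without a firm direction. For compound 4 the estimated value is 15000 nM, with an expected range of 4000 nM to 60000 nM.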

Compound 4, half-maximal inhibitory concentration: 34200 nM
Estimate against measurement, compound 4: 2.3-fold (0.36 log units) below; the range from low to high includes it.
By their numbers in this assay, from the lowest: compounds 3, 1 and 4 (each within the scatter of the next, the first and the last beyond it). At a limit, above all of these: compound 2.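

In this assay, going by these compounds alone, the earlier compounds carried only substituted phenyl groups at this place, and 1H-indol-3-yl shows that a group with a five-membered aromatic ring and no hydrogen-bond acceptors can also give a value in the same range as compound 1, with a 1.5-fold higher number from compound 1 to compound 4 (0.18 log units; within the scatter). The exchange is not neutral against the 2,3-dimethoxyphenyl group, with a 2.9-fold higher number from compound 3 to compound 4 (0.46 log units; beyond the scatter), while the 3,4-dimethoxyphenyl group compares differently, with an at least 3.7-fold lower number from compound 2 to compound 4 (0.57 log units; beyond the scatter). That last step is only a bound, and the value of compound 2 is a limit: the limit of > 128000 nM in this assay, at which 1 of the 4 values shown sits.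

As far as these compounds go, whether the hydrogen-bond donor of 1H-indol-3-yl contributes to the value remains open, as the exchange also changes the ring and removes both methoxy groups. From the compounds shown here alone, how an amine or a carboxylic acid on the aromatic group at this place would read also remains open.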